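This account rests on a few compounds, and the source may have more. Where it says the series, first, only, none or still open, it means among the compounds named here.

Measured so far in a functional assay on SK-OV-3 cells (Homo sapiens) for cytotoxicity; on this read-out higher numbers stand for weaker inhibition and lower numbers for stronger inhibition:
- compound 1 `Cc1nn(C)c(-n2ccc3ccccc32)c1/C=N/OCc1ccc(C(=O)OC(C)(C)C)cc1` gives 2.07 ug/mL
- compound 2 `Cc1nn(C)c(N2CCCC2)c1/C=N/OCc1ccc(C(=O)OC(C)(C)C)cc1` gives 3.19 ug/mL

The values of compound 1 and compound 2 lie within the scatter of each other, so compound 2 cannot be separated from compound 1 on these numbers. Compound 3 `Cc1nn(C)c(-n2cccn2)c1/C=N/OCc1ccc(C(=O)OC(C)(C)C)cc1` is still unmeasured. It differs from compound 2 as follows: 1H-pyrazol-1-yl in place of pyrrolidin-1-yl on an aromatic carbon. In words, 1H-pyrazol-1-yl stands in place of pyrrolidin-1-yl on an aromatic carbon, next to the ring nitrogen.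

For the measured compounds named here, only one measured step bears on this change. It is a 1.5-fold higher number from compound 1 to compound 2 (0.19 log units; within the scatter), which exchanges 1H-indol-1-yl for pyrrolidin-1-yl on the same aromatic carbon and stays within the scatter. Going by the values given here, no compound with 1H-pyrazol-1-yl has been measured, and a single step is thin evidence. Even so, no step beyond the scatter is expected in this assay, and no firm direction can be given. The estimated step is a 1.2-fold lower number from compound 2 to compound 3 (0.09 log units; within the scatter) and remains within the scatter. For compound 3 the expected value is 2.6 ug/mL, with an estimated range of 1.2 ug/mL to 5.6 ug/mL.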

Compound 3, half-maximal inhibitory concentration: 9.63 ug/mL
Compound 3: the middle estimate sits 3.7-fold (0.57 log units) below what was measured; the measured number lies above the stated range.
By their numbers in this assay, from the lowest: compounds 1 and 2 (each within the scatter of the next); then compound 3.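

Unlike the earlier pair, this position in this assay now shows a change that separates from the scatter: 1H-pyrazol-1-yl in place of pyrrolidin-1-yl gives a 3.0-fold higher number from compound 2 to compound 3 (0.48 log units; beyond the scatter) and, set against the indole, 1H-pyrazol-1-yl in place of 1H-indol-1-yl gives a 4.7-fold higher number from compound 1 to compound 3 (0.67 log units; beyond the scatter) on the same aromatic carbon. The position therefore does not tolerate every five-membered ring equally, and the aromatic character of the attached ring does not sort the three compounds by itself, since compound 1 also carries an aromatic ring there yet stays within the scatter of compound 2. No measurement at hand accounts for the weaker inhibition seen with 1H-pyrazol-1-yl.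

From the compounds shown here alone, it remains open whether the shift belongs to the pyrazole alone or extends to other aromatic azoles such as 1H-imidazol-1-yl and 1H-1,2,4-triazol-1-yl, and whether saturated rings such as morpholin-4-yl or piperidin-1-yl stay with pyrrolidin-1-yl. The far end of the molecule is also untested by these compounds, as all three share the tert-butyl ester and give no reading on a free carboxylic acid or an amide there.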